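The source may report more compounds than this note shows. Statements on the series, on what has been measured and on what is new or still open speak of the compounds shown alone.

Of the compounds shown here, two of a shared core have been measured in an assay on isolated protein for inhibition of protein kinase C zeta type (Homo sapiens), with stated times of 1 h and 2.5 min, tested at 30 uM; on this read-out higher numbers stand for more inhibition at the one concentration tested (going by the name of the read-out) and lower numbers for less inhibition. Compound 1, `CCOC(=O)c1c(-c2cccc(C#N)c2)csc1N`, carries a 3-cyanophenyl group and an ethyl ester; in this assay compound 1 gives 32%. Compound 2, `COc1ccc(-c2csc(N)c2C(=O)OCc2ccccc2)cc1`, carries a 4-methoxyphenyl group and a benzyl ester; in this assay compound 2 gives 86%. Of the two numbers, compound 2 stands highest, and the gap between compound 2 and compound 1 lies beyond the usual scatter of such measurements.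

The step now taken leads from compound 2 to compound 3, `N#Cc1cccc(-c2csc(N)c2C(=O)OCc2ccccc2)c1`. The change is 3-cyanophenyl in place of 4-methoxyphenyl on an aromatic carbon; the benzyl ester of compound 2 is kept. For the measured compounds named here, compound 1 and compound 3 share the 3-cyanophenyl group but differ in the ester, so the two cannot be joined into a step; the two values of compound 1 and compound 2 only show that the one measured compound bearing 3-cyanophenyl sits well below the one bearing 4-methoxyphenyl.

On that basis a drop is expected, with the step of a number 34 percentage points lower from compound 2 to compound 3 (beyond the scatter) estimated to lie beyond the scatter. For compound 3 the expected value in this assay is 52%, within a range from 25% to 80%.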

Compound 3, a percentage reported as inhibition, at one concentration (the size of the read-out at that concentration, not a potency): 25%
Compound 3: the middle estimate sits 27 percentage points above what was measured; measured number inside the range.
By their numbers in this assay, from the lowest: compounds 3 and 1 (each within the scatter of the next); then compound 2.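

In this assay the benzyl ester is held fixed across the step (a number 61 percentage points lower from compound 2 to compound 3 (beyond the scatter)), so this large fall can be read directly as the result of 3-cyanophenyl in place of 4-methoxyphenyl on this aromatic carbon of the shared core. Compound 1 and compound 2 differ in two places and could not show this. The second step (a number 7 percentage points lower from compound 1 to compound 3 (within the scatter)) stays within the scatter, so with 3-cyanophenyl in place, the ethyl ester and the benzyl ester cannot be told apart on this read-out.

No measurement shown here accounts for the size of the aryl effect. From the compounds shown here alone, it remains open whether the fall follows the change from methoxy to nitrile or the different place of that group on the phenyl ring, which 4-cyanophenyl or 3-methoxyphenyl could separate, and whether the ester matters when 4-methoxyphenyl is present, as an ethyl ester or a carboxylic acid there could show.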